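The source may hold more compounds than are shown below. What is called first, only, known or untested is meant among the compounds shown, and "the series" means these compounds.

Compound 1, with the structure `Cc1ccc(F)cc1S(=O)(=O)N1CCN(c2ccc(C(=O)NCc3ccc(F)cc3)nn2)CC1`, was tested in an ADME assay on microsomes from liver (Mus musculus) for metabolic stability, read by LC-MS, using NADPH, tested at 10 uM (on this read-out lower numbers stand for a shorter-lived compound and higher numbers for a longer-lived compound), where compound 1 gives 1.13 h. For the measured compounds named here, the only other measured compound, compound 2, with the structure `O=C(NCc1ccc(F)cc1)c1ccc(N2CC3(C2)CN(S(=O)(=O)c2cccnc2Cl)C3)nn1`, was tested in the same way, and in this assay compound 2 gives 1.88 h. These two numbers lie within the scatter of each other, so the two compounds cannot be told apart on this read-out.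

Compound 3, with the structure `Nc1ncccc1S(=O)(=O)N1CCN(c2ccc(C(=O)NCc3ccc(F)cc3)nn2)CC1`, has not yet been measured. It differs from compound 1 in one place: 2-aminopyridin-3-yl in place of 5-fluoro-2-methylphenyl on a sulfonyl sulfur. Going by the values given here, no measured pair in this set shows the same change, so there is no direct guide to its effect. The step from compound 1 to compound 3 in this assay is expected to be small, a 1.4-fold higher number from compound 1 to compound 3 (0.15 log units; within the scatter), pointing upward but close to the usual scatter. Compound 3 is accordingly expected to give about 1.6 h, within a range from 0.8 h to 3.2 h.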

Compound 3, half-life: 0.317 h
Compound 3: the middle estimate sits 5.0-fold (0.70 log units) above what was measured; the measured number lies below the stated range.
By their numbers in this assay, from the lowest: compound 3; then compounds 1 and 2 (each within the scatter of the next).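

In this assay, the group on the sulfonyl sulfur proves able to move the half-life: replacing 5-fluoro-2-methylphenyl with 2-aminopyridin-3-yl gives a 3.6-fold lower number from compound 1 to compound 3 (0.55 log units; beyond the scatter), a step beyond the scatter with the rest of the molecule unchanged. This single change therefore goes with a shorter-lived compound, even though the two groups are close in size and neither carries a net charge. No measurement here gives a reason for this step.

The compounds shown leave open which part of the swap accounts for the step, since the amino group and the ring nitrogen enter while the methyl and the fluorine leave together. A plain phenyl or a pyridin-3-yl without the amino group at this position would help separate these parts.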